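The source may hold more compounds than are shown below. What is called first, only, known or untested is meant among the compounds shown, and "the series" means these compounds.

The measured compounds in a functional assay on DLD-1 cells (Homo sapiens) for cytotoxicity, read by MTT assay, with a stated time of 72 h (on this read-out higher numbers stand for weaker inhibition and lower numbers for stronger inhibition), are these:
compound 1 `Cc1c(/N=C/c2cccc(O)c2)c(=O)n(-c2ccccc2)n1C` gives 372000000 nM
compound 2 `COc1cccc(/C=N/c2c(C)n(C)n(-c3ccccc3)c2=O)c1` gives 832000000 nM
compound 3 `COc1ccc(/C=N/c2c(C)n(C)n(-c3ccccc3)c2=O)cc1OC` gives 676000000 nM

All three share one core, and the numbers are all very high, meaning the inhibition seen in this assay is weak throughout. Compound 4 `COc1cc(/C=N/c2c(C)n(C)n(-c3ccccc3)c2=O)ccc1O` is not yet measured in this assay. It differs from compound 3 by hydrogen in place of methyl on an oxygen on an aromatic ring. The same change has been made once before here, from compound 2 to compound 1, where it is hydrogen in place of methyl on an oxygen on an aromatic ring and gave a 2.2-fold lower number from compound 2 to compound 1 (0.35 log units; beyond the scatter). The place of the change is described in the same words for both pairs, so it counts as the same change. The two starting points differ, though: compound 3 differs from compound 2 by methoxy in place of hydrogen on an aromatic carbon, a step that gave a 1.2-fold lower number from compound 2 to compound 3 (0.09 log units; within the scatter). With a single earlier example, the expectation for compound 4 rests on that one step, and compound 4 is expected to show a 2.2-fold lower number from compound 3 to compound 4 (0.34 log units; beyond the scatter) against compound 3 because of a 2.2-fold lower number from compound 2 to compound 1 (0.35 log units; beyond the scatter). For compound 4 the estimated value in this assay is 310000000 nM, most likely between 150000000 nM and 650000000 nM.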

Compound 4, half-maximal inhibitory concentration: 759000000 nM
Compound 4: middle estimate off by 2.4-fold (0.39 log units), on the low side, outside the stated range (above it).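

In this assay the swap of methoxy to hydroxy gave a 1.1-fold higher number from compound 3 to compound 4 (0.05 log units; within the scatter) and, set against the earlier case of this change, the two results cannot be told apart: the same change on two cores in this assay, a 2.2-fold lower number (0.35 log units; beyond the scatter) from compound 2 to compound 1 and a 1.1-fold higher number (0.05 log units; within the scatter) from compound 3 to compound 4, 2.5-fold (0.40 log units) apart, within the scatter of two such steps

Adding a hydroxy group to the aromatic ring gave a 1.1-fold lower number from compound 2 to compound 4 (0.04 log units; within the scatter) and this step also stays within the usual spread of repeated measurements. The result does not show that the change behaves differently on the two cores, but it does not show that the drop seen on the core of compound 2 carries over either, and two pairs are too few to settle the matter.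

The compounds shown leave open what other groups would do in that place, such as an amine or a carboxylic acid instead of the hydroxy. They also leave open whether any change to the shared core could bring the numbers down from the very high range seen in all four compounds.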